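Series notes: aryl exchange on the shared core

A few compounds are considered here, and "the series" means these few. Any claim that something is new, unique, unknown or untested is made for them only; others in the source may bear on it.

For the measured compounds named here, compound 1 `CC(C)c1ccc(-c2nc3sccn3c2/C=N/OCc2ccc(Cl)c(Cl)c2)cc1` is the only member of the series with a number in an assay on HepG2 cells for agonist activity at nuclear receptor subfamily 1 group I member 3 (Homo sapiens), read by a luciferase reporter, with a stated time of 23 h; on this read-out higher numbers stand for an effect only at larger amounts of compound and lower numbers for an effect already at smaller amounts: there compound 1 gives 590 nM. Compound 2 `CC1(C)CCC(C)(C)c2cc(-c3nc4sccn4c3/C=N/OCc3ccc(Cl)c(Cl)c3)ccc21` is reported in this assay as "not active" (no number reported), and compound 3 `Clc1ccc(CO/N=C/c2c(-c3ccc(-c4ccccc4)cc3)nc3sccn23)cc1Cl` likewise as "not active" (no number reported). Going by the values given here, no pair of measured compounds differs in a single place, so no measured step is available.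

Compound 4 `Clc1ccc(CO/N=C/c2c(-c3ccc4ccccc4c3)nc3sccn23)cc1Cl` is not yet measured. It differs from compound 1 by naphthalen-2-yl in place of 4-isopropylphenyl on an aromatic carbon. Among the compounds with values here, both compounds that carry a different group at this position in place of 4-isopropylphenyl are without a number, which gives no direction from measured steps; the expectation rests on compound 1 alone together with the outcome for compound 2 and compound 3. The step from compound 1 to compound 4 is expected to be a 5.1-fold higher number from compound 1 to compound 4 (0.71 log units; beyond the scatter), a loss beyond the scatter, because compound 3 gives "not active" (no number reported) in this assay. For compound 4 the estimate in this assay is 3000 nM, with a range from 900 nM to 15000 nM, and a substantial chance that only a limit is reported.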

Compound 4, half-maximal effective concentration: 380 nM
Beside the measured number, compound 4's estimate is 7.9-fold (0.90 log units) above it; measured number outside the range, below it.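

For the compounds shown here, at this position of the shared core, 4-isopropylphenyl is not the only group that gives a number in this assay: naphthalen-2-yl in its place gives a 1.6-fold lower number from compound 1 to compound 4 (0.19 log units; within the scatter), so the two groups cannot be told apart in this assay. The "not active" entries for compound 2 and compound 3 therefore do not extend to every replacement of 4-isopropylphenyl on this aromatic carbon. Nothing measured here accounts for why compound 4 keeps a number while compound 2 and compound 3 have none.

Open, on these data alone, is how a plain phenyl, a 4-tert-butylphenyl or a quinolin-2-yl group would read at this position, and whether an amine or a carboxylic acid on the aryl ring would leave a number at all. The compounds shown also leave open whether the tolerance for naphthalen-2-yl holds with any other group on the rest of the core.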